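The source may report more compounds than this note shows. Statements on the series, on what has been measured and on what is new or still open speak of the compounds shown alone.

Working notes on the aryloxyacetohydrazone series.

For the measured compounds named here, compound 3 `O=C(COc1cccc2ccccc12)N/N=C/C=C/c1ccccc1` gives 4.43 in a physicochemical assay for lipophilicity, measured as octanol-water partition (a lower number here means a more polar compound, a higher number a more lipophilic compound), the highest value among the three compounds measured so far. Going by the values given here, the nearest is compound 2 `O=C(COc1cccc2ccccc12)N/N=C/c1cccc([N+](=O)[O-])c1`, which gives 3.97 in this assay; the two values differ by more than the scatter, though no single-point step links them. Among the compounds with values here, the furthest is compound 1 `O=C(COc1cccc2ccccc12)N/N=C/c1ccc(O)cc1`, which gives 3.73; the only measured step, a number 0.70 log units higher from compound 1 to compound 3 (beyond the scatter), records a modest rise beyond the scatter for 2-phenylethenyl in place of 4-hydroxyphenyl on a carbon with a double bond to nitrogen.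

Compound 4 `O=C(COc1cccc2ccccc12)N/N=C/c1cccc(Cl)c1` is not yet measured. Its difference from compound 3 is 3-chlorophenyl in place of 2-phenylethenyl on a carbon with a double bond to nitrogen. Within the data shown here, no measured step covers this exchange directly. Among the measured compounds shown here, the one step that touches the same carbon, a number 0.70 log units higher from compound 1 to compound 3 (beyond the scatter), concerns a hydroxyl-bearing aryl group and does not transfer; compound 2, carrying a nitro group at the same position, sits below compound 3 but above compound 1. Both groups exchanged here carry no hydrogen-bond donor or acceptor, so a step of no more than the scatter is expected in this assay, in either direction. For compound 4 the estimate is 4.35, within 4.05 to 4.65; this corresponds to an expected step of a number 0.08 log units lower from compound 3 to compound 4 (within the scatter).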

Compound 4, partition coefficient: 4.54
The estimate for compound 4 lay 0.19 log units below the measured number; the measured number falls inside the stated range.
By their numbers in this assay, from the lowest: compounds 1 and 2 (each within the scatter of the next); then compounds 3 and 4 (each within the scatter of the next).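

At this place, on a carbon with a double bond to nitrogen, 3-chlorophenyl and 2-phenylethenyl cannot be told apart in this assay (a number 0.11 log units higher from compound 3 to compound 4 (within the scatter)), even though the two groups differ in heavy atoms and only 2-phenylethenyl has a double bond outside the aromatic ring. The group on the aromatic ring does matter in compound 2 and compound 4, which differ only in that place: chloro in place of nitro on an aromatic carbon gives a step beyond the scatter (a number 0.57 log units higher from compound 2 to compound 4 (beyond the scatter)). The step for 3-chlorophenyl in place of 4-hydroxyphenyl (a number 0.81 log units higher from compound 1 to compound 4 (beyond the scatter)) stands with the earlier one for 2-phenylethenyl in place of 4-hydroxyphenyl (a number 0.70 log units higher from compound 1 to compound 3 (beyond the scatter)), so compound 1 lies beyond the scatter from both compound 3 and compound 4.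

No evidence on the reason for these steps is at hand. Still open, from the compounds shown here alone, is whether an amine or a carboxylic acid on the aromatic carbon that carries chloro in compound 4 would move the number as far as the nitro or the hydroxyl compounds do, and whether a longer chain in place of 2-phenylethenyl would stay within the scatter of compound 3.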